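Secondary Amide to Tertiary Amide on a Weak Series

A few compounds are considered here, and "the series" means these few. Any claim that something is new, unique, unknown or untested is made for them only; others in the source may bear on it.

The shared core is that of compound 1 `Cc1ccc(N2C(=O)N/C(=C\c3ccc(O)cc3)C2=O)cc1`, which in a functional assay on NCI-H292 cells (Homo sapiens) for antiproliferative activity (a lower number here means a stronger inhibitor, a higher number a weaker inhibitor), gives 27900 nM. Compound 2 `O=C(NCC1CCCCC1)c1ccc(N2C(=O)N/C(=C\c3ccc(O)cc3)C2=O)cc1` carries a (cyclohexylmethyl)carbamoyl in place of the methyl on an aromatic carbon. In this assay compound 2 reaches only the limit of > 200000 nM, so no number is known for it. The step of an at least 7.1-fold higher number from compound 1 to compound 2 (0.85 log units; beyond the scatter) is defined only against that limit (the limit of > 200000 nM in this assay, at which 1 of the 2 values shown sits), and compound 2 stands at the weak end of the two values seen. Compound 3 `O=C(c1ccc(N2C(=O)N/C(=C\c3ccc(O)cc3)C2=O)cc1)N1CCCC1` differs from compound 2 by pyrrolidin-1-yl in place of (cyclohexylmethyl)amino on a carbonyl carbon. For the measured compounds named here, the only measured step that bears on this change is an at least 7.1-fold higher number from compound 1 to compound 2 (0.85 log units; beyond the scatter), and no measured pair compares one amide with another. In this assay compound 3 is therefore expected to remain weak, with the step of an at least 1.3-fold lower number from compound 2 to compound 3 (0.12 log units; that floor lies within the scatter) expected to fall within the scatter. The estimate for compound 3 is 150000 nM, ranging from 40000 nM to 600000 nM, with a real chance that only a limit is reported again.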

Compound 3, half-maximal inhibitory concentration: > 200000 nM
Compound 3: only a limit was reported (the forecaster's own chance of this, stated with the estimate: 55%); middle value at least 1.3-fold (0.12 log units) from the limit.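

On the aromatic carbon that carries the methyl in the shared core, a second amide, this time (pyrrolidin-1-yl)carbonyl, gives an at least 7.1-fold higher number from compound 1 to compound 3 (0.85 log units; beyond the scatter) in this assay. The loss of activity is therefore not peculiar to (cyclohexylmethyl)carbamoyl: it appears with both amides shown, including pyrrolidin-1-yl, which has no hydrogen-bond donor and no six-membered carbon ring. The step between the two amides cannot be read, and they now share the ceiling of the assay: the limit of > 200000 nM in this assay, at which 2 of the 3 values shown sit.

From the compounds shown here alone, it remains open how weak either amide really is, and so whether the choice of amine on the carbonyl carbon matters at all. Going by these compounds, it is also open whether the amide link itself goes with the loss, or whether a group such as a carboxylic acid, a methyl ester or a simple chlorine atom at this position would match or improve on compound 1, which gives 27900 nM.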